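The compounds below may be only part of what the source reports. "The series", "measured", "known", "first", "only" and "open" are said of these compounds alone.

In a functional assay on MGC-803 cells (Homo sapiens) for inhibition, read by MTT assay, with a stated time of 48 h (a lower number here means a stronger inhibitor, a higher number a weaker inhibitor), compound 1 `Cc1ccc(NC(=S)NC(=O)c2ccc(OCc3cccc(C(F)(F)F)c3)cc2)cc1-c1nc2ccccc2[nH]1` gives 5210 nM and compound 2 `Cc1ccc(NC(=S)NC(=O)c2ccc(OCc3ccccc3F)cc2)cc1-c1nc2ccccc2[nH]1` gives 3070 nM. Among the measured compounds shown here, the pair shows a 1.7-fold lower number from compound 1 to compound 2 (0.23 log units; within the scatter), so compound 2 stands level with the only other true number available. Compound 3 `Cc1ccc(NC(=S)NC(=O)c2ccc(OCc3cccc(Cl)c3Cl)cc2)cc1-c1nc2ccccc2[nH]1` reads > 100000 nM, which is a limit of the assay and not a number. The steps into that limit are large: an at least 19-fold higher number from compound 1 to compound 3 (1.28 log units; beyond the scatter) and an at least 32-fold higher number from compound 2 to compound 3 (1.51 log units; beyond the scatter).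

Compound 4 `Cc1ccc(NC(=S)NC(=O)c2ccc(OCc3ccc(Cl)c(Cl)c3)cc2)cc1-c1nc2ccccc2[nH]1` is still unmeasured. In it, a 3,4-dichlorophenyl takes the place of the 2-fluorophenyl on a saturated chain carbon bound to an oxygen on an aromatic ring: 3,4-dichlorophenyl in place of 2-fluorophenyl on a saturated chain carbon bound to an oxygen on an aromatic ring. The only measured dichlorophenyl case points upward, with an at least 32-fold higher number from compound 2 to compound 3 (1.51 log units; beyond the scatter). Yet the swap of this ring seen in a 1.7-fold lower number from compound 1 to compound 2 (0.23 log units; within the scatter) stayed within the scatter. A moderate move towards a higher number is therefore expected in this assay, with a real chance of another limit. The expected step is a 2.6-fold higher number from compound 2 to compound 4 (0.42 log units; beyond the scatter). For compound 4 the estimated value is 8000 nM, with an expected range from 2000 nM to 60000 nM.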

Compound 4, half-maximal inhibitory concentration: 6390 nM
Estimate against measurement, compound 4: 1.3-fold (0.10 log units) above, and the stated range covers the measured number.
By their numbers in this assay, from the lowest: compounds 2, 1 and 4 (each within the scatter of the next, the first and the last beyond it). At a limit, above all of these: compound 3.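

At this position in this assay, two chlorines on the ring do not in themselves carry the number up to the limit, since 3,4-dichlorophenyl in place of 2,3-dichlorophenyl brings a large drop (an at least 15-fold lower number from compound 3 to compound 4 (1.19 log units; beyond the scatter)). The value of compound 3 in that step is a limit of the assay and not a number: the limit of > 100000 nM in this assay, at which 1 of the 4 values shown sits. The 3,4-dichlorophenyl stands level with 3-(trifluoromethyl)phenyl (a 1.2-fold higher number from compound 1 to compound 4 (0.09 log units; within the scatter)) and only a modest step from 2-fluorophenyl (a 2.1-fold higher number from compound 2 to compound 4 (0.32 log units; beyond the scatter)), so among these four compounds the steep loss belongs to compound 3 alone.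

The compounds shown leave open how a single chlorine, a methoxy group, an amine or a carboxylic acid on this ring would read. They also leave open whether any group here can bring the number clearly lower than that of compound 2.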